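The source may hold more compounds than are shown below. What is called first, only, known or untested is meant among the compounds shown, and "the series" means these compounds.

Compound 1 `N#CC1CN1C(=O)Nc1ccc(F)cc1` was tested in a functional assay on RPMI-8226 cells (Homo sapiens) for inhibition (a higher number here means a weaker inhibitor, a lower number a stronger inhibitor), where compound 1 gives 5000 nM. Compound 2 `N#CC1CN1C(=O)Nc1cccc2ccccc12` gives 8000 nM in this assay. Compound 1 holds the lower of these two numbers, yet the gap to compound 2 lies within the usual scatter, so the two cannot be told apart. Compound 3 `N#CC1CN1C(=O)Nc1ccc(C(F)(F)F)cc1` differs from compound 1 by trifluoromethyl in place of fluoro on an aromatic carbon. Among the compounds with values here, no measured pair shows a change of this kind, so nothing here points in either direction, and no step beyond the scatter is expected. Compound 3 is therefore expected to give about 5000 nM in this assay, within a range of 2000 nM to 12000 nM. This expectation means a step of no change at the digits printed from compound 1 to compound 3 (within the scatter).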

Compound 3, half-maximal inhibitory concentration: 8200 nM
Estimate against measurement, compound 3: 1.6-fold (0.21 log units) below, and the stated range covers the measured number.
By their numbers in this assay, from the lowest: compounds 1, 2 and 3 (each within the scatter of the next).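

Putting trifluoromethyl in place of fluoro on this aromatic carbon gives a 1.6-fold higher number from compound 1 to compound 3 (0.21 log units; within the scatter) in this assay. At this position, para to a group of 8 heavy atoms, a substituent of 4 heavy atoms therefore gives a number that cannot be told apart from that of a substituent of 1 heavy atom. No measurement at hand bears on why these two groups read alike.

From the compounds shown here alone, whether an amine or a carboxylic acid at this position would move the number beyond the scatter stays open. So does whether a longer chain here would do so.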